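A few compounds are considered here, and "the series" means these few. Any claim that something is new, unique, unknown or untested is made for them only; others in the source may bear on it.

Measured so far in a functional assay on A375-C5 cells (Homo sapiens) for inhibition, read by sulforhodamine B assay, with a stated time of 48 h; a lower number here means a stronger inhibitor of growth, a higher number a weaker inhibitor of growth:

- Compound 1 `COC(=O)c1sc2cc(C#Cc3ccc(OC)cc3)cnc2c1N`: > 37500 nM, a limit of this assay.
- Compound 2 `COC(=O)c1sc2cc(C#Cc3ccccc3OC)cnc2c1N`: > 47300 nM, a limit of this assay.
- Compound 3 `COC(=O)c1sc2cc(C#Cc3ccsc3)cnc2c1N`: 29600 nM, the only number among the three.

Going by the values given here, compound 3 thus stands as the sole read value; the other two entries are limits. Compound 4 `COC(=O)c1sc2cc(C#Cc3ccccc3N)cnc2c1N` changes it by 2-aminophenyl in place of thiophen-3-yl on a triple-bonded carbon. Among the compounds with values here, the steps that bear on this are an at least 1.2-fold lower number from compound 1 to compound 3 (0.10 log units; that floor lies within the scatter) and an at least 1.5-fold lower number from compound 2 to compound 3 (0.20 log units; that floor lies within the scatter), both floors that lie within the scatter, while a step that the two limits leave unreadable from compound 1 to compound 2 stays unreadable. Two substituted phenyls on the triple-bonded carbon therefore gave limits where the thiophen-3-yl gave a number. For compound 4 a move toward a higher number is expected, plausibly back to a limit, of about a 1.4-fold higher number from compound 3 to compound 4 (0.13 log units; within the scatter). The expected value for compound 4 is 40000 nM, within 15000 nM to 100000 nM.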

Compound 4, concentration for 50% growth inhibition: 3100 nM
Compound 4: the middle estimate sits 13-fold (1.11 log units) above what was measured; the whole stated range lies above it.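

In this assay, this position on the triple-bonded carbon now shows its first step beyond the scatter: 2-aminophenyl in place of thiophen-3-yl gives a 9.5-fold lower number from compound 3 to compound 4 (0.98 log units; beyond the scatter). The swap of amino for methoxy on an aromatic carbon gives an at least 15-fold lower number from compound 2 to compound 4 (1.18 log units; beyond the scatter), and 2-aminophenyl in place of 4-methoxyphenyl gives an at least 12-fold lower number from compound 1 to compound 4 (1.08 log units; beyond the scatter), so among these compounds the group carried on the phenyl ring separates a limit from a low number. Both of those steps are floors; compound 2, for one, stands at a limit: the limit of > 47300 nM in this assay, at which 1 of the 4 values shown sits.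

The compounds shown leave open how 4-aminophenyl, 2-hydroxyphenyl or 2-acetamidophenyl would read at this position.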